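Rearranging the Anilide Ring, With Cytotoxicity Still Expected Low

The compounds below may be only part of what the source reports. "The series", "measured", "known", "first", "only" and "open" are said of these compounds alone.

In an ADME assay on NCM460 cells (Homo sapiens) for cytotoxicity, read by MTT assay, with a stated time of 72 h (on this read-out higher numbers stand for weaker inhibition and lower numbers for stronger inhibition), compound 1 `COc1ccc(NC(=O)c2cccc(/C=C3\CC(=O)N(c4ccccc4)C3=O)c2)c(C)c1` gives only a limit, > 100000 nM. Compound 2 `CCCCCN1C(=O)C/C(=C\c2cccc(C(=O)Nc3ccc(OC)cc3)c2)C1=O` likewise gives only a limit in this assay, > 100000 nM. Among the compounds with values here, compound 1 thus stands only at the limit of > 100000 nM in this assay, at which 2 of the 2 values shown sit, with no number behind it, and no measured step between compounds exists. Compound 3 `CCOc1ccc(NC(=O)c2cccc(/C=C3\CC(=O)N(c4ccccc4)C3=O)c2)cc1` differs from compound 1 by 4-ethoxyphenyl in place of 4-methoxy-2-methylphenyl on an amide-type nitrogen. The step is expected to be a number no higher from compound 1 to compound 3 (the limit leaves the size open), nothing beyond the usual scatter. Compound 3 is therefore estimated at 100000 nM, between 50000 nM and 200000 nM, and most likely again reported only as a limit.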

Compound 3, half-maximal inhibitory concentration: > 100000 nM
Compound 3: a limit, no number; the forecaster's own chance of this, stated with the estimate: 80%; the middle value lies on the limit itself.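

No step can be read from compound 1 to compound 3, as both results are limits and not numbers: the limit of > 100000 nM in this assay, at which 3 of the 3 values shown sit.

On these data alone, whether 4-ethoxyphenyl in place of 4-methoxy-2-methylphenyl changes the read-out at all in this assay stays open.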